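Trading a methoxy group for two chlorines: what to expect

The source may hold more compounds than are shown below. What is called first, only, known or untested is meant among the compounds shown, and "the series" means these compounds.

Measured so far in a functional assay on MRC5 cells (Homo sapiens); on this read-out lower numbers stand for higher toxicity in this test and higher numbers for lower toxicity in this test:
Compound 1 `COc1ccc(CN2C(=O)c3ccccc3N(Cc3ccc(OC)cc3)S2(=O)=O)cc1`: 57000 nM
Compound 2 `COc1ccc(CN2c3ccccc3C(=O)N(Cc3ccccc3)S2(=O)=O)cc1`: 61000 nM
Compound 3 `O=C1c2ccccc2N(Cc2ccc(Cl)cc2)S(=O)(=O)N1Cc1ccc(Cl)cc1`: 56000 nM

The three numbers form a tight cluster. Compound 2 sits at the upper end of it, but its gap to compound 1 and its gap to compound 3 are both within the scatter, so the three compounds cannot be told apart on this assay.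

Compound 4 `O=C1c2ccccc2N(Cc2ccc(Cl)c(Cl)c2)S(=O)(=O)N1Cc1ccccc1` has not yet been measured. It differs from compound 2 in one place: 3,4-dichlorophenyl in place of 4-methoxyphenyl on a saturated chain carbon bound to a sulfonamide nitrogen in a ring.

For the measured compounds named here, only one measured step touches the same part of the shared core, the one from compound 1 to compound 2, which was a 1.1-fold higher number from compound 1 to compound 2 (0.03 log units; within the scatter). Compound 3, which carries a chlorinated ring on the same saturated chain carbon, returns a number indistinguishable from that of compound 2 as well. None of the available data point toward a change beyond the scatter, so the expected step of a 1.1-fold lower number from compound 2 to compound 4 (0.02 log units; within the scatter) is a flat one. Compound 4 is therefore estimated at 58000 nM in this assay, within a range from 28000 nM to 120000 nM.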

Compound 4, half-maximal cytotoxic concentration: 56000 nM
Compound 4: the middle estimate sits 1.0-fold (0.02 log units) above what was measured; the measured number falls inside the stated range.
By their numbers in this assay, from the lowest: compounds 3, 4, 1 and 2 (each within the scatter of the next).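

In this assay, exchanging 4-methoxyphenyl for 3,4-dichlorophenyl on a saturated chain carbon bound to a sulfonamide nitrogen in a ring gives a 1.1-fold lower number from compound 2 to compound 4 (0.04 log units; within the scatter), so the two compounds cannot be told apart on this read-out. This goes further than the earlier step in this part of the core, which only replaced a methoxy group with hydrogen: here the group that leaves has one hydrogen-bond acceptor, the group that enters has none and brings two chlorines, and the result still stays within the scatter. No supporting measurement is available to explain this flat result.

The compounds shown carry only methoxy or chlorine on these aromatic rings, so it remains open whether an amine or a carboxylic acid on the ring would give a number beyond the scatter. As far as these compounds go, it is also open whether a longer chain carrying the same 3,4-dichlorophenyl group would stay just as flat in this assay.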